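The compounds below may be only part of what the source reports. "The series", "measured", "known", "first", "only" and "open" are said of these compounds alone.

Measured so far in a functional assay on MDA-MB-231 cells (Homo sapiens) for cytotoxicity, read by MTT assay, with a stated time of 72 h; a higher number here means a weaker inhibitor, a lower number a stronger inhibitor:
compound 1 `COc1cc2c(Oc3ccc(NC(=O)N/N=C/c4ccc(F)cc4Cl)cc3F)ccnc2cc1OCCCN1CCCCC1` — 790 nM
compound 2 `COc1cc2c(Oc3ccc(NC(=O)N/N=C/c4ccc(Cl)cc4Cl)cc3F)ccnc2cc1OCCCN1CCCCC1` — 750 nM
compound 3 `COc1cc2c(Oc3ccc(NC(=O)N/N=C/c4ccc(Cl)cc4Cl)cc3F)ccnc2cc1OCCCN1CCC(C)CC1` — 910 nM

The three numbers in this assay lie within the scatter of one another, so no order among compound 1, compound 2 and compound 3 is claimed. Compound 3 differs from compound 2 by methyl in place of hydrogen on a saturated ring carbon, a step of a 1.2-fold higher number from compound 2 to compound 3 (0.08 log units; within the scatter). Compound 1 differs from compound 2 by fluoro in place of chloro on an aromatic carbon, a step of a 1.1-fold higher number from compound 2 to compound 1 (0.02 log units; within the scatter).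

Compound 4 `COc1cc2c(Oc3ccc(NC(=O)N/N=C/c4ccc(F)cc4Cl)cc3F)ccnc2cc1OCCCN1CCC(C)CC1` is not yet measured. It differs from compound 3 by fluoro in place of chloro on an aromatic carbon, the same change as that from compound 2 to compound 1, made here on the core of compound 3. For compound 4 the step from compound 3 is expected to be a 1.0-fold higher number from compound 3 to compound 4 (0.01 log units; within the scatter), resting on the earlier step of a 1.1-fold higher number from compound 2 to compound 1 (0.02 log units; within the scatter), which stayed within the scatter. Compound 4 is therefore estimated at 930 nM, with the range 500 nM to 1800 nM.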

Compound 4, half-maximal inhibitory concentration: 1500 nM
Beside the measured number, compound 4's estimate is 1.6-fold (0.21 log units) below it; measured number inside the range.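

Fluoro in place of chloro on an aromatic carbon, 2,4-dichlorophenyl to 2-chloro-4-fluorophenyl, gives in this assay a step of a 1.6-fold higher number from compound 3 to compound 4 (0.22 log units; within the scatter) and reads alike on the two cores: the same change on two cores in this assay, a 1.1-fold higher number (0.02 log units; within the scatter) from compound 2 to compound 1 and a 1.6-fold higher number (0.22 log units; within the scatter) from compound 3 to compound 4, 1.6-fold (0.19 log units) apart, within the scatter of two such steps. Methyl in place of hydrogen on a saturated ring carbon gives a 1.9-fold higher number from compound 1 to compound 4 (0.28 log units; within the scatter) and also reads alike on the two cores: the same change on two cores in this assay, a 1.2-fold higher number (0.08 log units; within the scatter) from compound 2 to compound 3 and a 1.9-fold higher number (0.28 log units; within the scatter) from compound 1 to compound 4, 1.6-fold (0.19 log units) apart, within the scatter of two such steps. Both changes therefore carry between these cores without a difference that stands clear of the scatter, but this rests on a single square of four compounds and does not show that either change moves the number at all or that it would carry to other cores.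

Still open, going by these compounds, is whether a nitrile or a methoxy group in place of the fluoro would give a step beyond the scatter. The same holds for an ethyl group or a hydroxyl in place of the methyl on the saturated ring.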